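The source may hold more compounds than are shown below. What is called first, only, known or untested is meant among the compounds shown, and "the series" means these compounds.

Measured so far, in a functional assay on MCF7 cells (Homo sapiens) for inhibition, read by sulforhodamine B assay; on this read-out higher numbers stand for weaker inhibition of growth and lower numbers for stronger inhibition of growth:
- compound 1 `Cc1ccc2[nH]c(-c3ccc(-c4ccc(-c5cccc(Cl)c5)cc4)cc3)nc2c1`: 1210 nM
- compound 2 `COc1ccc(-c2ccc(-c3ccc(-c4nc5cc(C)ccc5[nH]4)cc3)cc2)cc1OC`: 190 nM
- compound 3 `Cc1ccc2[nH]c(-c3ccc(-c4ccc(-c5ccc(C(F)(F)F)cc5)cc4)cc3)nc2c1`: 31000 nM

Compound 3 carries the highest of the three numbers, so it inhibits growth the least. Both other compounds lie well below it.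

The next compound, compound 4 `Cc1ccc2[nH]c(-c3ccc(-c4ccc(-c5ccc(O)cc5)cc4)cc3)nc2c1`, has hydroxy in place of trifluoromethyl on an aromatic carbon, para to a large group (hydroxy in place of trifluoromethyl on an aromatic carbon). In other words, 4-(trifluoromethyl)phenyl becomes 4-hydroxyphenyl.

The three measured compounds differ only in this end group, so their steps are the best guide. Two steps install the group that compound 4 removes, and both are large: a 26-fold higher number from compound 1 to compound 3 (1.41 log units; beyond the scatter) and a 160-fold higher number from compound 2 to compound 3 (2.21 log units; beyond the scatter). The step between the two other end groups is smaller, at a 6.4-fold lower number from compound 1 to compound 2 (0.80 log units; beyond the scatter). So far, then, 4-(trifluoromethyl)phenyl is the one end group that stands apart, although three compounds are a thin basis. Among the measured compounds shown here, no compound with a hydroxy group has been measured, which leaves the size of the step uncertain.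

A large step towards stronger inhibition is expected, estimated as a 31-fold lower number from compound 3 to compound 4 (1.49 log units; beyond the scatter). For compound 4 the estimated value is 1000 nM, with an expected range from 150 nM to 8000 nM.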

Compound 4, concentration for 50% growth inhibition: 12100 nM
Beside the measured number, compound 4's estimate is 12-fold (1.08 log units) below it; measured number outside the range, above it.
By their numbers in this assay, from the lowest: compound 2; then compound 1; then compound 4; then compound 3.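

In this assay, replacing trifluoromethyl with hydroxy at this place brings only a modest gain (a 2.6-fold lower number from compound 3 to compound 4 (0.41 log units; beyond the scatter)), so removing trifluoromethyl does not by itself restore the stronger growth inhibition of the other compounds. Compound 4 also remains far from the compounds with the other two end groups (a 64-fold higher number from compound 2 to compound 4 (1.80 log units; beyond the scatter)) (a 10-fold higher number from compound 1 to compound 4 (1.00 log units; beyond the scatter)), so 4-(trifluoromethyl)phenyl no longer stands alone: 4-hydroxyphenyl also sits on the weak side, though the gap to 3-chlorophenyl is smaller than the gap to 3,4-dimethoxyphenyl. No supporting measurement is available to explain why these end groups differ so much.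

The compounds shown leave open whether a single group at this place, para to a large group, can ever match 3,4-dimethoxyphenyl, since only trifluoromethyl and hydroxy have been seen there. A single methoxy group or an amine in the same place would help to show whether compound 2 owes its lower number to methoxy itself or to having two groups on that ring.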